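From Methylsulfanyl to Dimethylamino on an Aromatic Ring

This account rests on a few compounds, and the source may have more. Where it says the series, first, only, none or still open, it means among the compounds named here.

- Compound 1 `CCN(c1ccc(OC)cc1)c1ncnc2occ(C)c12`: 812 nM
- Compound 2 `CSc1ccc(N(C)c2ncnc3occ(C)c23)cc1`: 520 nM

In a functional assay on Chorioallantoic membrane (Gallus gallus, strain Leghorn), read by microscopy, with a stated time of 40 h (on this read-out higher numbers stand for weaker inhibition and lower numbers for stronger inhibition), compound 2 gives 520 nM and compound 1 gives 812 nM. These two numbers lie within the usual scatter of repeated measurements, so the data cannot rank the two compounds.

The next compound to be tested is compound 3 `Cc1coc2ncnc(N(C)c3ccc(N(C)C)cc3)c12`. Compared with compound 2, it has dimethylamino in place of methylsulfanyl on an aromatic carbon, para to a large group: dimethylamino in place of methylsulfanyl on an aromatic carbon.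

Among the compounds with values here, no measured pair of compounds differs in just one place, so the data do not show directly what this swap does. The only hint is weak: compound 1 at 812 nM and compound 2 at 520 nM stay within the scatter of each other, even though they differ in more than one place. In this assay, no shift beyond the scatter is therefore expected, in either direction. The expected change is a 1.2-fold lower number from compound 2 to compound 3 (0.06 log units; within the scatter). For compound 3, the estimated value is 450 nM, with an expected range of 150 nM to 1400 nM.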

Compound 3, half-maximal inhibitory concentration: 653 nM
Compound 3: the middle estimate sits 1.5-fold (0.16 log units) below what was measured; low and high end bracket the measured number.
By their numbers in this assay, from the lowest: compounds 2, 3 and 1 (each within the scatter of the next).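

Within the data shown here, this is the first pair that differs in one place only. In this assay, dimethylamino in place of methylsulfanyl on an aromatic carbon, para to a large group, gives a 1.3-fold higher number from compound 2 to compound 3 (0.10 log units; within the scatter) and stays within the scatter, so the two compounds cannot be told apart. At this position, then, the swap adds one heavy atom, exchanges sulfur for nitrogen, and keeps the counts of hydrogen-bond donors and acceptors and the net charge the same, without any shift the assay can resolve. No separate measurement bears on why these two groups read alike.

On these data alone, what a more different group on this same carbon would do stays open, for instance a carboxylic acid, a primary amine or a longer alkyl chain, any of which could show whether the number can move beyond the scatter here at all. As far as these compounds go, compound 1 differs from compound 2 in more than one place, and the separate contributions of its ethyl and methoxy groups remain unknown.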